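The source may report more compounds than this note shows. Statements on the series, on what has been measured and on what is new or still open speak of the compounds shown alone.

Measured in a functional assay on HeLa cells (Homo sapiens) for cytotoxicity, read by MTT assay, with a stated time of 48 h (on this read-out higher numbers stand for weaker inhibition and lower numbers for stronger inhibition), so far:
compound 1 `O=C(Nc1nc2ccc(Cl)cc2s1)c1cc(-c2ccc(F)cc2)n2nc(-c3ccccc3)cc2n1` gives 9770 nM
compound 2 `COc1ccc(-c2cc(C(=O)Nc3nc4ccc(Cl)cc4s3)nc3cc(-c4ccccc4)nn23)cc1` gives 5880 nM
compound 3 `Cc1cc2nc(NC(=O)c3cc(-c4ccc(F)cc4)n4nc(-c5ccccc5)cc4n3)sc2cc1C` gives 18200 nM

Compound 2 differs from compound 1 by methoxy in place of fluoro on an aromatic carbon; the step is a 1.7-fold lower number from compound 1 to compound 2 (0.22 log units; within the scatter). Compound 3 differs from compound 1 in its core, by 5,6-dimethyl-1,3-benzothiazol-2-yl in place of 6-chloro-1,3-benzothiazol-2-yl on an amide-type nitrogen; the step is a 1.9-fold higher number from compound 1 to compound 3 (0.27 log units; within the scatter). Compound 3 holds the highest of the three numbers, but its gap to compound 1 is within the scatter, so no order between those two can be claimed; only its gap to compound 2 lies beyond the scatter.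

Compound 4 `COc1ccc(-c2cc(C(=O)Nc3nc4cc(C)c(C)cc4s3)nc3cc(-c4ccccc4)nn23)cc1` is not yet measured in this assay. It differs from compound 3 by methoxy in place of fluoro on an aromatic carbon, which is the same change as that from compound 1 to compound 2, at a place described in the same words, and the only other instance of it among these compounds. The difference is that it now sits on the core of compound 3 rather than on the core of compound 1. With a single measured instance there is no way to tell whether the core alters the size of this step, so the expectation is simply carried over.

The step expected here is a 1.7-fold lower number from compound 3 to compound 4 (0.23 log units; within the scatter), resting on a 1.7-fold lower number from compound 1 to compound 2 (0.22 log units; within the scatter). Compound 4 is accordingly estimated at 10700 nM. For compound 4 the expected range runs from 5000 nM to 24000 nM, wide enough to cover a step that falls anywhere within the scatter.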

Compound 4, half-maximal inhibitory concentration: 14100 nM
Estimate against measurement, compound 4: 1.3-fold (0.12 log units) below; low and high end bracket the measured number.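

In this assay the change from 4-fluorophenyl to 4-methoxyphenyl on the core of compound 3 gives a 1.3-fold lower number from compound 3 to compound 4 (0.11 log units; within the scatter) and matches the same change on the core of compound 1: the same change on two cores in this assay, a 1.7-fold lower number (0.22 log units; within the scatter) from compound 1 to compound 2 and a 1.3-fold lower number (0.11 log units; within the scatter) from compound 3 to compound 4, 1.3-fold (0.11 log units) apart, within the scatter of two such steps.
Going by these compounds alone, the exchange of 6-chloro-1,3-benzothiazol-2-yl for 5,6-dimethyl-1,3-benzothiazol-2-yl, read with methoxy in place, gives a 2.4-fold higher number from compound 2 to compound 4 (0.38 log units; beyond the scatter) and also matches its earlier instance, although only this later step lies beyond the scatter: the same change on two cores in this assay, a 1.9-fold higher number (0.27 log units; within the scatter) from compound 1 to compound 3 and a 2.4-fold higher number (0.38 log units; beyond the scatter) from compound 2 to compound 4, 1.3-fold (0.11 log units) apart, within the scatter of two such steps.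
Across these four compounds, each change therefore carries from one core to the other without a detectable difference in step size, but this rests on one pair of instances per change, says nothing about cores outside the set, and cannot establish a real effect of the methoxy change, whose two steps both lie within the scatter.

Still open, as far as these compounds go, is whether a group such as an amine, a carboxylic acid or a longer chain in place of methoxy on that aromatic ring would give a step beyond the scatter. From the compounds shown here alone, it is equally open whether such a step, or the benzothiazolyl exchange, would carry over as closely on a third core.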